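The source may hold more compounds than are shown below. What is called first, only, known or untested is meant among the compounds shown, and "the series" means these compounds.

Compound 1, `COc1cc2c(Oc3ccc(NC(=O)c4cc(-c5ccccc5F)ccn4)cc3F)ccnc2cc1OCCCN1CCN(C)CC1`, is the starting point. For the measured compounds named here, in a functional assay on MKN-45 cells (Homo sapiens) for cytotoxicity, read by MTT assay, with a stated time of 72 h (on this read-out higher numbers stand for weaker inhibition and lower numbers for stronger inhibition), compound 1 gives 150 nM, and among the three compounds measured so far its number sits at the low end. Its two neighbours keep the same core and differ only in the ring attached to the pyridine-amide part. Compound 2, `COc1cc2c(Oc3ccc(NC(=O)c4cc(-c5ccc(C(F)(F)F)cc5)ccn4)cc3F)ccnc2cc1OCCCN1CCN(C)CC1`, carries a 4-(trifluoromethyl)phenyl there and gives 330 nM; the step of a 2.2-fold higher number from compound 1 to compound 2 (0.34 log units; beyond the scatter) lies beyond the scatter. Compound 3, `COc1ccc(-c2ccnc(C(=O)Nc3ccc(Oc4ccnc5cc(OCCCN6CCN(C)CC6)c(OC)cc45)c(F)c3)c2)cc1`, carries a 4-methoxyphenyl and gives 250 nM; the step of a 1.7-fold higher number from compound 1 to compound 3 (0.22 log units; within the scatter) stays within the scatter, as does a 1.3-fold lower number from compound 2 to compound 3 (0.12 log units; within the scatter).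

Compound 4, `COc1cc2c(Oc3ccc(NC(=O)c4cc(-c5ccccc5F)ccn4)cc3F)ccnc2cc1OCCCN1CCCC1`, takes a different route. It keeps the 2-fluorophenyl of compound 1 untouched and instead changes the far end of the side chain: pyrrolidin-1-yl in place of 4-methylpiperazin-1-yl on a saturated chain carbon, three bonds along the chain from an oxygen on an aromatic ring. Going by the values given here, none of the measured steps touches this part of the molecule; all three move the aromatic substituent on the other side of the core, so they give no direct guide to what this swap will do. With nothing pointing either way, the step from compound 1 to compound 4 in this assay is expected to be small, and a 1.1-fold higher number from compound 1 to compound 4 (0.03 log units; within the scatter) is the estimate, meaning no change beyond the scatter. Compound 4 is therefore expected to give about 160 nM, with a plausible range from 60 nM to 450 nM.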

Compound 4, half-maximal inhibitory concentration: 230 nM
Estimate against measurement, compound 4: 1.4-fold (0.16 log units) below; the range from low to high includes it.
By their numbers in this assay, from the lowest: compounds 1, 4, 3 and 2 (each within the scatter of the next, the first and the last beyond it).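

For the compounds shown here, this is the first reading at the far end of the side chain. In this assay the change gives a 1.5-fold higher number from compound 1 to compound 4 (0.19 log units; within the scatter) and so cannot be told apart from repeat measurements. With the 2-fluorophenyl in place, the 4-methylpiperazin-1-yl can therefore give way to the smaller pyrrolidin-1-yl, a five-membered ring with one nitrogen instead of a six-membered ring with two, and the number stays within the scatter. Nothing measured here explains why the swap leaves the number within the scatter.

Going by these compounds alone, this swap is seen on only one pair, so it remains open whether it would read the same alongside the 4-(trifluoromethyl)phenyl of compound 2 or the 4-methoxyphenyl of compound 3. Also open, as far as these compounds go, is how this assay would respond to other groups at the end of the chain, such as morpholin-4-yl or a plain dimethylamino, or to a chain longer than the propyl that compound 1 and compound 4 share.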